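The source may report more compounds than this note shows. Statements on the series, on what has been measured and on what is new or still open speak of the compounds shown alone.

Within the data shown here, compound 2 `CC1=C(O)[C@H](C/C(C)=C\CC[C@H](C)/C=C/C=C(\C)CCCC2=CC(=O)N(CCC(C)C)C2)OC1=O` gives 30 ug/mL in a functional assay on XF498 cells (Homo sapiens) for cytotoxicity (a higher number here means that more compound is needed for the effect, a lower number that less compound is needed), the highest of the two numbers measured so far. Compound 1 `CC1=C(O)[C@H](C/C(C)=C\CC[C@H](C)/C=C/C=C(\C)CCCC2=CCN(CCC(C)C)C2=O)OC1=O` gives 5.5 ug/mL in this assay, and the step of a 5.5-fold higher number from compound 1 to compound 2 (0.74 log units; beyond the scatter) shows that exchanging the ring group at this position of the chain shifts the number by a modest amount. Compound 3 `COC1C=C(CCC/C(C)=C/C=C/[C@@H](C)CC/C=C(/C)C[C@@H]2OC(=O)C(C)=C2O)C(=O)O1` differs from compound 2 by a group of 8 heavy atoms (5 carbon, 3 oxygen; one five-membered non-aromatic ring with 1 hetero atom) in place of a group of 11 heavy atoms (9 carbon, 1 nitrogen, 1 oxygen; one five-membered non-aromatic ring with 1 hetero atom), on a saturated chain carbon, three bonds along the chain from a double-bonded chain carbon. Among the measured compounds shown here, no measured pair covers this particular exchange; the only step that bears on it is the one from compound 1 to compound 2, a modest one at the same place. The step of a 2.0-fold lower number from compound 2 to compound 3 (0.30 log units; within the scatter) is therefore expected to be modest as well, with its direction uncertain. For compound 3 the value in this assay is estimated at 15 ug/mL, with a range from 3 ug/mL to 60 ug/mL.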

Compound 3, concentration for half-maximal effect: 20.1 ug/mL
Compound 3: the middle estimate sits 1.3-fold (0.13 log units) below what was measured, within the range that was stated.
By their numbers in this assay, from the lowest: compound 1; then compounds 3 and 2 (each within the scatter of the next).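

In this assay, the 8-atom group with three oxygens and no nitrogen gives a result that cannot be told apart from that of the 11-atom nitrogen-containing group of compound 2 (a 1.5-fold lower number from compound 2 to compound 3 (0.17 log units; within the scatter)). A nitrogen in the ring group is therefore not required to reach this level, and the two quite different groups sit together, while the step of a 3.7-fold higher number from compound 1 to compound 3 (0.56 log units; beyond the scatter) leaves compound 1 with the lowest number of the three. Nothing given here explains why the ring group of compound 1 stands apart.

Only three ring groups at this place of the chain are shown, so the trend cannot be extended to others. Going by these compounds, whether an amine, a carboxylic acid or a longer chain on the ring nitrogen would give a number lower than that of compound 1 remains open.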